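The source may hold more compounds than are shown below. What is called first, only, known or untested is meant among the compounds shown, and "the series" means these compounds.

Working notes on the series.

Compound 1 `COc1ccc(C(=O)/C=C/c2cc(-c3cc(OC)c(OC)c(OC)c3)n[nH]2)cc1OC` is measured in a functional assay on A549 cells (Homo sapiens) for cytotoxicity, read by sulforhodamine B assay, with a stated time of 48 h, tested at 0.01 uM (a higher number here means a weaker effect of the compound at the concentration tested, a lower number a stronger effect), where compound 1 gives 98%. Among the measured compounds shown here, compound 2 `COc1cc(-c2cc(/C=C/C(=O)c3ccc(F)c(F)c3)[nH]n2)cc(OC)c1OC` is the only other measured member; in this assay compound 2 gives 101%. For the measured compounds named here, on these two numbers compound 1 stands lowest, with compound 2 its nearest neighbour, and the one measured step, a number 3 percentage points higher from compound 1 to compound 2 (within the scatter), is the exchange of the aryl on the carbonyl carbon: 3,4-difluorophenyl in place of 3,4-dimethoxyphenyl. That step stays within the scatter, so the aryl on the carbonyl carbon has not moved the read-out here.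

Compound 3 `COc1cc(C(=O)/C=C/c2cc(-c3cc(OC)c(OC)c(OC)c3)n[nH]2)cc(OC)c1OC` is not yet measured in this assay. It differs from compound 1 by methoxy in place of hydrogen on an aromatic carbon. Going by the values given here, the only step that bears on it is the one from compound 1 to compound 2, which also alters the aryl on the carbonyl carbon and did not leave the scatter. Both measured values sit close to no effect at this concentration. For compound 3 the step of a number 1 percentage points higher from compound 1 to compound 3 (within the scatter) is therefore expected to stay within the scatter, with no direction favoured. The estimate for compound 3 in this assay is 99%, expected between 90% and 108%.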

Compound 3, a percentage reported as activity, at one concentration (the size of the read-out at that concentration, not a potency): 97%
Estimate against measurement, compound 3: 2 percentage points above; low and high end bracket the measured number.
By their numbers in this assay, from the lowest: compounds 3, 1 and 2 (each within the scatter of the next).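

In this assay the step to the third methoxy, a number 1 percentage points lower from compound 1 to compound 3 (within the scatter), stays within the scatter, so a methoxy in place of hydrogen on this aromatic carbon, ortho to a methoxy group and meta to a large group, leaves the read-out where it was. The earlier step exchanged the whole aryl on the carbonyl carbon, whereas this one keeps that aryl and changes a single place on it, and at this concentration compound 3, at 97%, still sits close to no effect, so this place shows no sensitivity to the change in this read-out. Nothing on hand bears on why the read-out holds at this position.

With all the values this close to no effect, the compounds shown leave open whether this position matters at all under conditions where the series gives a clear effect, since a flat read-out here cannot separate a tolerated change from an inactive series. Also open, as far as these compounds go, is how this aromatic carbon responds to a group of another kind, such as a hydroxy, an amine, a carboxylic acid or a longer alkoxy chain.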